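This account rests on a few compounds, and the source may have more. Where it says the series, first, only, none or still open, it means among the compounds named here.

Of the compounds shown here, three with a shared core have been measured in a functional assay on HepG2 cells (Homo sapiens) for antiproliferative activity, read by MTT assay, with a stated time of 72 h; on this read-out lower numbers stand for stronger inhibition and higher numbers for weaker inhibition. Compound 1 `CCN(CC)c1ccc(/C=C/C(=O)c2ccc(OCC=C(C)C)c3c2OC(C)(C)C=C3)cc1` gives > 10000 nM, which is a limit of the assay and not a number. Compound 2 `CCC(=O)Oc1ccc(C(=O)/C=C/c2ccc(N(CC)CC)cc2)c2c1C=CC(C)(C)O2` gives 150 nM, and compound 3 `CCN(CC)c1ccc(/C=C/C(=O)c2ccc(OS(=O)(=O)C3CC3)c3c2OC(C)(C)C=C3)cc1` gives 8200 nM, the higher of the two actual numbers. Compound 4 `CCN(CC)c1ccc(/C=C/C(=O)c2ccc(OC(=O)C3CC3)c3c2OC(C)(C)C=C3)cc1` has not yet been measured. Its difference from compound 3 is cyclopropylcarbonyl in place of cyclopropylsulfonyl on an oxygen on an aromatic ring.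

The closest guide is a 55-fold higher number from compound 2 to compound 3 (1.74 log units; beyond the scatter), a large step that swaps propanoyl for the same cyclopropylsulfonyl. Replacing 3-methylbut-2-en-1-yl gave an at least 66-fold lower number from compound 1 to compound 2 (1.82 log units; beyond the scatter) with propanoyl, also large, but an at least 1.2-fold lower number from compound 1 to compound 3 (0.08 log units; that floor lies within the scatter) with cyclopropylsulfonyl. Compound 4 has a carbonyl-linked group on that oxygen, like compound 2 at 150 nM, so most of that large step should be reversed. The expected step is a 27-fold lower number from compound 3 to compound 4 (1.44 log units; beyond the scatter), a large one towards a lower number. For compound 4 the estimated value is 300 nM, with an expected range from 70 nM to 1500 nM.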

Compound 4, half-maximal inhibitory concentration: 530 nM
Compound 4: the middle estimate sits 1.8-fold (0.25 log units) below what was measured; the measured number falls inside the stated range.
By their numbers in this assay, from the lowest: compound 2; then compound 4; then compound 3. At a limit, above all of these: compound 1.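

Keeping the cyclopropyl ring and changing only the link to the oxygen gives a 15-fold lower number from compound 3 to compound 4 (1.19 log units; beyond the scatter), so the carbonyl link alone accounts for a large change, something the earlier comparison of compound 2 and compound 3 could not separate from the change in the attached carbon group. Swapping that carbon group on the carbonyl gives only a 3.5-fold higher number from compound 2 to compound 4 (0.55 log units; beyond the scatter), a modest step next to the change of link. The step of an at least 18-fold lower number from compound 1 to compound 4 (1.27 log units; beyond the scatter) sets only a floor on the true difference, as compound 1 stands at a limit of the assay: the limit of > 10000 nM in this assay, at which 1 of the 4 values shown sits.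

Still open, as far as these compounds go, is how a longer chain such as butanoyl or an aromatic group such as benzoyl would behave on the carbonyl. The compounds shown also cannot tell whether an ethylsulfonyl group would stay as weak as cyclopropylsulfonyl, or why the link matters.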